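Amine swap on the alkoxy chain: expectation for compound 4

The source may hold more compounds than are shown below. What is called first, only, known or untested is meant among the compounds shown, and "the series" means these compounds.

The compounds share a core carrying a basic amine at the end of an alkoxy chain. Compound 3 `CN1CCN(CCCOc2c(OCc3ccccc3)cc3oc(-c4ccccc4)cc(=O)c3c2O)CC1` gives 4100 nM in a functional assay on BCG823 cells (Homo sapiens) for antiproliferative activity, read by MTT assay, with a stated time of 48 h; a higher number here means a weaker inhibitor, a lower number a stronger inhibitor. Compound 1 `O=c1cc(-c2ccccc2)oc2cc(OCc3ccccc3)c(OCCCN3CCCC3)c(O)c12` differs from it by pyrrolidin-1-yl in place of 4-methylpiperazin-1-yl on a saturated chain carbon, three bonds along the chain from an oxygen on an aromatic ring. Compound 1 reaches only the limit of this assay, > 100000 nM. That change made an at least 24-fold higher number from compound 3 to compound 1 (1.38 log units; beyond the scatter), and the step is open at one end because of the limit of > 100000 nM in this assay, at which 1 of the 3 values shown sits.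

Compound 2 `CN1CCN(CCCCOc2c(O)cc3oc(-c4ccccc4)cc(=O)c3c2O)CC1` gives 82900 nM in this assay, the higher of the two numbers, with compound 3 some distance lower. The difference between the cores of compound 2 and compound 3 is not broken down here.

Compound 4 `O=c1cc(-c2ccccc2)oc2cc(O)c(OCCCCN3CCCC3)c(O)c12` has not yet been measured in this assay. Against compound 2 it carries pyrrolidin-1-yl in place of 4-methylpiperazin-1-yl on a saturated chain carbon, four bonds along the chain from an oxygen on an aromatic ring. This is the same kind of change as that from compound 3 to compound 1, not the same: there the group sits three bonds along the chain from an oxygen on an aromatic ring, here four bonds along the chain from an oxygen on an aromatic ring. Starting from compound 2 at 82900 nM, a step of comparable direction and size is expected, namely a 2.2-fold higher number from compound 2 to compound 4 (0.34 log units; beyond the scatter), resting on the earlier at least 24-fold higher number from compound 3 to compound 1 (1.38 log units; beyond the scatter). Compound 4 is therefore expected to give about 180000 nM in this assay, plausibly between 60000 nM and 600000 nM, and quite possibly to register only as a limit.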

Compound 4, half-maximal inhibitory concentration: 86400 nM
Estimate against measurement, compound 4: 2.1-fold (0.32 log units) above, within the range that was stated.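

In this assay, pyrrolidin-1-yl in place of 4-methylpiperazin-1-yl, four bonds along the chain from an oxygen on an aromatic ring, gives a 1.0-fold higher number from compound 2 to compound 4 (0.02 log units; within the scatter), a step that shows no effect of the swap on this core. The large step seen on the other core therefore does not carry over in size, and a value read on one core is a poor guide to the other: the same change on two cores in this assay, an at least 24-fold higher number (1.38 log units; beyond the scatter) from compound 3 to compound 1 and a 1.0-fold higher number (0.02 log units; within the scatter) from compound 2 to compound 4, at least 23-fold (1.36 log units) apart, beyond the scatter of two such steps. Among the compounds shown here, this rests on only two pairs, which differ both in where the amine sits on the chain and in the rest of the core, and it does not show which of these differences sets the gap, nor that the swap is without effect on other cores.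

Going by these compounds, compound 1 stands at a limit of the assay, > 100000 nM, and the true size of its step stays open at the upper end. Also open, on these data alone, is how another amine, such as piperidin-1-yl or morpholin-4-yl, or a longer chain would read on these two cores, and whether a benzyloxy group on the core of compound 2 would bring back the larger step.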